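Swapping the sulfur-linked ring for a carbon-linked one

The source may hold more compounds than are shown below. What is called first, only, known or untested is meant among the compounds shown, and "the series" means these compounds.

In an assay on HEK cells for antagonist activity at transient receptor potential cation channel subfamily V member 1 (Homo sapiens), read by FLIPR (on this read-out higher numbers stand for weaker inhibition and lower numbers for stronger inhibition), three compounds sharing one core have been measured. Compound 1 `CCCN(CCC)c1nc(C(F)(F)F)ccc1CNC(=O)Nc1cccc2[nH]c(=O)ccc12` gives 5.21 nM. Compound 2 `O=C(NCc1ccc(C(F)(F)F)nc1OCc1ccccc1)Nc1cccc2[nH]c(=O)ccc12` gives 1.2 nM, and compound 3 `O=C(NCc1ccc(C(F)(F)F)nc1SC1CCCCC1)Nc1cccc2[nH]c(=O)ccc12` gives 2.15 nM. The steps between them are all modest: a 4.3-fold lower number from compound 1 to compound 2 (0.64 log units; beyond the scatter) and a 2.4-fold lower number from compound 1 to compound 3 (0.38 log units; beyond the scatter) lie beyond the scatter, whereas a 1.8-fold higher number from compound 2 to compound 3 (0.25 log units; within the scatter) stays within it. Compound 3 thus stands second highest of the three numbers, close to compound 2 and further from compound 1.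

Compound 4 `CC1CCC(c2nc(C(F)(F)F)ccc2CNC(=O)Nc2cccc3[nH]c(=O)ccc23)CC1` is not yet measured. Its difference from compound 3 is 4-methylcyclohexyl in place of cyclohexylsulfanyl on an aromatic carbon. Within the data shown here, the steps that bear on this change are those in which the same position was altered, namely a 2.4-fold lower number from compound 1 to compound 3 (0.38 log units; beyond the scatter) and a 1.8-fold higher number from compound 2 to compound 3 (0.25 log units; within the scatter): three quite different groups at this position give numbers spread over only a small span. Among the measured compounds shown here, no measured step shows a carbon-linked ring here, so the direction is uncertain. The change is therefore expected to give at most a small step, a 1.5-fold higher number from compound 3 to compound 4 (0.17 log units; within the scatter), as likely to fall within the scatter as beyond it. For compound 4 the estimate in this assay is 3.2 nM, with a range from 1 nM to 10 nM.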

Compound 4, half-maximal inhibitory concentration: 1.44 nM
Estimate against measurement, compound 4: 2.2-fold (0.35 log units) above; low and high end bracket the measured number.
By their numbers in this assay, from the lowest: compounds 2, 4 and 3 (each within the scatter of the next); then compound 1.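

In this assay, the position next to the ring nitrogen accepts a ring joined directly through carbon, with no sulfur or oxygen linking atom: the change shows a 1.5-fold lower number from compound 3 to compound 4 (0.17 log units; within the scatter) and the comparison with the benzyloxy compound shows a 1.2-fold higher number from compound 2 to compound 4 (0.08 log units; within the scatter), so 4-methylcyclohexyl cannot be told apart from cyclohexylsulfanyl or benzyloxy. Among these compounds only dipropylamino stands apart, and the new compound confirms this with a 3.6-fold lower number from compound 1 to compound 4 (0.56 log units; beyond the scatter), which makes three groups with different linking atoms that sit together against that one group. Nothing in the data given bears on why replacing the sulfur-linked ring with a carbon-linked one leaves the number within the scatter.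

The compounds shown do not separate the effect of the methyl group from that of the direct carbon link, since a plain cyclohexyl ring attached directly at this position does not appear among them. From the compounds shown here alone, it also remains open how far this tolerance reaches, as the series includes no small group such as methyl and no carboxylic acid or morpholine ring at this position.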